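The source may report more compounds than this note shows. Statements on the series, on what has been measured and on what is new or still open speak of the compounds shown alone.

Working notes on the series. Of the compounds shown here, two have been measured in a physicochemical assay for lipophilicity, in phosphate buffer, measured as octanol-water partition; on this read-out higher numbers stand for higher lipophilicity and lower numbers for lower lipophilicity. Compound 1 `COc1ccccc1NC(=S)NC(=O)Nc1ccc2c(c1)C(=O)C(=O)N2Cc1ccccc1` gives 2.38 in this assay. Compound 2 `Cc1cccc(NC(=S)NC(=O)Nc2ccc3c(c2)C(=O)C(=O)N3Cc2ccccc2Cl)c1` gives 3.72 in this assay, the higher of the two numbers, with compound 1 standing a gap below it that lies beyond the scatter. Compound 1 and compound 2 differ in two places, so no single step can be read from this pair.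

Compound 3 `COc1ccccc1NC(=S)NC(=O)Nc1ccc2c(c1)C(=O)C(=O)N2Cc1ccccc1Cl` has not yet been measured. It differs from compound 2 in one place: 2-methoxyphenyl in place of 3-methylphenyl on an amide-type nitrogen. Compound 3 and compound 1 share the 2-methoxyphenyl group on that nitrogen and differ only on the other side of the core. Within the data shown here, no measured pair isolates this change. For compound 3 a modest decrease in this assay is expected, a number 0.62 log units lower from compound 2 to compound 3 (beyond the scatter), and it is estimated at 3.1, with a range from 2.6 to 3.6.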

Compound 3, partition coefficient: 3.18
Compound 3: the middle estimate sits 0.08 log units below what was measured; the measured number falls inside the stated range.
By their numbers in this assay, from the lowest: compound 1; then compound 3; then compound 2.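

In this assay, the swap of 3-methylphenyl for 2-methoxyphenyl on the amide-type nitrogen can now be read on its own, as a number 0.54 log units lower from compound 2 to compound 3 (beyond the scatter). With the 2-methoxyphenyl group held fixed, chloro in place of hydrogen on an aromatic carbon can also be read on its own, as a number 0.80 log units higher from compound 1 to compound 3 (beyond the scatter). Nothing available on these compounds accounts for the size or direction of either step.

On these data alone, each change is seen only once, on a single partner group, so it remains open whether either step would hold if the group elsewhere on the molecule were different. Also open, as far as these compounds go, is how this assay would read with a fluoro group in place of the chloro, or with a carboxylic acid or an amine on the phenyl ring attached to that nitrogen.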